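The source may report more compounds than this note shows. Statements on the series, on what has been measured and on what is new or still open speak of the compounds shown alone.

Compound 3 `COc1ccc(N)c(C(O)CCNC(=N)c2ccc(Cl)cc2)c1` gives 81% in an assay for inhibition of Nitric oxide synthase, inducible (Homo sapiens), with a stated time of 30 min, tested at 1 mM; on this read-out higher numbers stand for more inhibition at the one concentration tested (going by the name of the read-out) and lower numbers for less inhibition. On the three numbers shown it stands second: compound 2 `COc1ccc(N)c(C(O)CCNC(=N)c2ccccc2)c1` gives 95.9%, and compound 1 `N=C(NCCC(O)c1ccccc1N)c1ccc(C(F)(F)F)cc1` gives 60.5%. Among the measured compounds shown here, the one measured step that bears on the present change is a number 14.9 percentage points lower from compound 2 to compound 3 (beyond the scatter), so adding a chloro where hydrogen had been lowered the read-out beyond the scatter.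

Compound 4 `COc1ccc(N)c(C(O)CCNC(=N)c2ccc(C(F)(F)F)cc2)c1` differs from compound 3 by trifluoromethyl in place of chloro on an aromatic carbon. For the measured compounds named here, no measured pair shows this exact change on the same core. Compound 1 carries the trifluoromethyl on a core without the methoxy and shows the lowest number of the three, but it differs from compound 2 in two places, so its value only hints that the trifluoromethyl does not raise the read-out.

From the direction of the step from compound 2 to compound 3, a further modest fall is expected for compound 4, of about a number 11 percentage points lower from compound 3 to compound 4 (beyond the scatter). Compound 4 is therefore estimated at 70%, with a plausible range from 50% to 88%.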

Compound 4, a percentage reported as inhibition, at one concentration (the size of the read-out at that concentration, not a potency): 99.6%
Compound 4: middle estimate off by 29.6 percentage points, on the low side; the whole stated range lies below it.
By their numbers in this assay, from the lowest: compound 1; then compound 3; then compounds 2 and 4 (each within the scatter of the next).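

When trifluoromethyl replaces chloro, this assay gives a number 18.6 percentage points higher from compound 3 to compound 4 (beyond the scatter) and so reverses the earlier fall seen with chloro. Trifluoromethyl in place of hydrogen gives a number 3.7 percentage points higher from compound 2 to compound 4 (within the scatter) and makes no clear difference, so on the shared core a substituent at this place does not in itself lower the read-out, with chloro the one group of the three that stands apart. With trifluoromethyl held fixed, methoxy in place of hydrogen gives a number 39.1 percentage points higher from compound 1 to compound 4 (beyond the scatter) and shows that the low number of compound 1 goes with the missing methoxy rather than with the trifluoromethyl.

From the compounds shown here alone, whether a nitrile or a methyl at this aromatic carbon would behave like chloro or like trifluoromethyl remains open. Nothing at hand explains why chloro and trifluoromethyl differ here.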